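A few compounds are considered here, and "the series" means these few. Any claim that something is new, unique, unknown or untested is made for them only; others in the source may bear on it.

Measured compounds:
compound 1 `CCc1nnc(-c2ccc(-c3ccccc3)cc2)n1-c1cccc(C)c1C` — 940 nM
compound 2 `CCc1nnc(-c2ccc(-c3ccccc3)cc2)n1-c1cccc(F)c1C` — 630 nM

Compound 2 has the lowest of the two numbers in an assay on C6 glioma cells for displacement of a labelled ligand from sodium- and chloride-dependent glycine transporter 1 (Rattus norvegicus), read by scintillation counting, with stated times of 30 min and 10 min (a higher number here means a weaker inhibitor, a lower number a stronger inhibitor), though compound 1 is within the scatter of it, with a 1.5-fold lower number from compound 1 to compound 2 (0.17 log units; within the scatter). Compound 3 `CCc1nnc(-c2ccc(-c3ccccc3)cc2)n1-c1cccc(C(=O)OC)c1C` carries methoxycarbonyl in place of fluoro on an aromatic carbon. Going by the values given here, no measured step involves a methoxycarbonyl group, and the one step known, the change from methyl to fluoro, was within the scatter, so it gives little guidance for a larger replacement. A modest weakening is expected, a 1.9-fold higher number from compound 2 to compound 3 (0.28 log units; within the scatter), with wide uncertainty. Compound 3 is thus estimated at 1200 nM in this assay, expected to fall between 400 nM and 4000 nM.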

Compound 3, half-maximal inhibitory concentration: 5100 nM
Beside the measured number, compound 3's estimate is 4.3-fold (0.63 log units) below it, outside the stated range (above it).
By their numbers in this assay, from the lowest: compounds 2 and 1 (each within the scatter of the next); then compound 3.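

In this assay, this aromatic carbon, ortho to a methyl group, proves sensitive to what it carries: methoxycarbonyl gives a clear loss (an 8.1-fold higher number from compound 2 to compound 3 (0.91 log units; beyond the scatter)) and also (a 5.4-fold higher number from compound 1 to compound 3 (0.73 log units; beyond the scatter)), whereas methyl and fluoro stayed within the scatter of each other. Of the three groups, only methoxycarbonyl moves the number beyond the scatter, so this position is not indifferent to substitution. Nothing available explains this loss. From the compounds shown here alone, whether a carboxylic acid, a primary amide or an ethyl group on this carbon would behave like methoxycarbonyl or like methyl and fluoro stays open.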